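A methoxy group takes the place of 1,3-benzoxazol-2-yl

This account rests on a few compounds, and the source may have more. Where it says the series, first, only, none or still open, it means among the compounds named here.

In a toxicity assay on NIH3T3 cells (Mus musculus) for cytotoxicity, read by resazurin assay (a lower number here means that less compound is needed, a higher number that more compound is needed for the effect), compound 1 `O=C(OC1CCCCC1)c1ccc(NCc2cncn2Cc2ccc(-c3ccccc3)cc2)cc1-c1ccccc1` gives > 10000 nM as a limit of the assay. Compound 2 `c1ccc(-c2ccc(Cn3cncc3CNc3ccc(-c4cncs4)c(-c4ccccc4)c3)cc2)cc1` gives > 1000 nM as a limit too. Compound 3 `c1ccc(-c2ccc(Cn3cncc3CNc3ccc(-c4nc5ccccc5o4)c(-c4ccccc4)c3)cc2)cc1` stands at > 10000 nM and this is again a limit rather than a number. Going to compound 4 `COc1ccc(NCc2cncn2Cc2ccc(-c3ccccc3)cc2)cc1-c1ccccc1` brings this change on an aromatic carbon ortho to a phenyl group: methoxy in place of 1,3-benzoxazol-2-yl on an aromatic carbon with methoxy in place of 1,3-benzoxazol-2-yl. Two measured swaps bear on it: a step that the two limits leave unreadable from compound 1 to compound 3 and a step that the two limits leave unreadable from compound 2 to compound 3 offer no size to build on. So the estimated step is a number no higher from compound 3 to compound 4 (the limit leaves the size open) and no direction beyond the scatter is expected in this assay here. The estimate for compound 4 is 10000 nM with an expected range from 3000 nM to 30000 nM and a reading at the assay limit is likely.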

Compound 4, half-maximal effective concentration: > 1000 nM
Compound 4 gave a limit, no number (the forecaster's own chance of this, stated with the estimate: 70%); the middle value lies beyond the limit too.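

Within the data shown here, compound 1, compound 2, compound 3 and compound 4 all give only limits, and no step among them can be read. The compounds shown leave open what concentration of any of them reaches half-maximal effect in this assay.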